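The source may report more compounds than this note shows. Statements on the series, on what has been measured and on what is new or still open speak of the compounds shown alone.

In an assay for binding affinity to Corticotropin releasing factor receptor (Rattus norvegicus) (a higher number here means a weaker inhibitor, a lower number a stronger inhibitor), compound 3 `CCCC(C)n1c(CC)nc2c(-c3ccc(C(C)(C)O)cc3Cl)ccnc21` gives 24 nM, which places it second highest of the three measured compounds: compound 2 `CCCC(C)n1c(CC)nc2c(-c3ccc(Cl)cc3Cl)ccnc21` gives 0.5 nM, and compound 1 `CCCC(C)n1c(CC)nc2c(-c3ccc(Cl)cc3C(C)=O)ccnc21` gives 95.6 nM. Compound 4 `CCCC(C)n1c(CC)nc2c(-c3ccc(/C(C)=N\OC)cc3Cl)ccnc21` differs from compound 3 in one place: a group of 5 heavy atoms (3 carbon, 1 nitrogen, 1 oxygen; no ring) in place of a group of 4 heavy atoms (3 carbon, 1 oxygen; no ring), on an aromatic carbon. Two measured steps at this ring inform the expectation. The step of a 190-fold lower number from compound 1 to compound 2 (2.28 log units; beyond the scatter) was large, and the step of a 48-fold higher number from compound 2 to compound 3 (1.68 log units; beyond the scatter) was also large and bears most directly, since it installed the very group that now leaves. Both steps show that replacing a group on this ring can move the number a long way in this assay, and in both the chloro-bearing compound 2 stands far below the other compound. Compound 4, like compound 3, carries a group that is not chloro at the changed carbon, so the step of a 1.7-fold higher number from compound 3 to compound 4 (0.22 log units; within the scatter) is expected to be modest, in either direction, and may fall within the scatter. The number for compound 4 is therefore estimated at 40 nM, with a range from 12 nM to 130 nM.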

Compound 4, inhibition constant: 2.3 nM
Beside the measured number, compound 4's estimate is 17-fold (1.24 log units) above it; the measured number lies below the stated range.
By their numbers in this assay, from the lowest: compound 2; then compound 4; then compound 3; then compound 1.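

In this assay, the size of a step at the aromatic carbon para to a large group does not depend on chloro leaving: exchanging 1-hydroxy-1-methylethyl for a non-ring group of 5 heavy atoms gives a 10-fold lower number from compound 3 to compound 4 (1.02 log units; beyond the scatter) and so is itself large. Chloro therefore has a much closer non-chloro replacement here than compound 3 showed, with a 4.6-fold higher number from compound 2 to compound 4 (0.66 log units; beyond the scatter) remaining beyond the scatter but modest, against a 48-fold higher number from compound 2 to compound 3 (1.68 log units; beyond the scatter) for the earlier replacement. The compounds shown offer no measurement that explains this difference.

The step from compound 3 to compound 4 removes a hydrogen-bond donor, adds a hydrogen-bond acceptor and adds a double bond all at once, so these changes cannot be separated. On these data alone, how an amine, a carboxylic acid or a longer alkyl chain at this carbon would compare remains open.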